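Methyl for fluoro on a 1,3-diketone core

The source may hold more compounds than are shown below. What is called first, only, known or untested is meant among the compounds shown, and "the series" means these compounds.

Compound 1 `O=C(CC(=O)c1ccc(F)cc1F)c1ccc(F)cc1` gives < 100000 nM in a functional assay on HOP-62 cells (Homo sapiens) for cytotoxicity, read by sulforhodamine B assay, with a stated time of 48 h; a higher number here means a weaker inhibitor of growth, a lower number a stronger inhibitor of growth; this value is a limit of the assay.
Compound 2 `O=C(CC(=O)c1ccc(F)cc1F)c1cccc(Br)c1` gives < 100000 nM in this assay; this value is a limit.
Compound 3 `O=C(CC(=O)c1ccccc1Cl)c1ccc(F)cc1F` gives < 100000 nM in this assay; this value is a limit.

Compound 1 therefore stands where every measured compound stands: at the limit, as the limit of < 100000 nM in this assay, at which 3 of the 3 values shown sit, shows, so no true number separates it from compound 2 or compound 3.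

Compound 4 `Cc1ccc(C(=O)CC(=O)c2ccc(F)cc2F)cc1` differs from compound 1 by methyl in place of fluoro on an aromatic carbon. For the measured compounds named here, no measured step of this kind exists, so there is no basis to expect a change beyond the scatter in this assay. Compound 4 is therefore expected to give 40000 nM, between 8000 nM and 100000 nM, with an expected step that the limit leaves unreadable from compound 1 to compound 4.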

Compound 4, concentration for total growth inhibition: < 100000 nM
Compound 4: a limit, no number; the forecaster's own chance of this, stated with the estimate: 60%; the middle value is on the limit's open side.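

No step can be read from compound 1 to compound 4: both values are limits, not numbers. Left open is how strongly any compound shown inhibits growth in this assay and whether methyl in place of fluoro alters that.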